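The source may report more compounds than this note shows. Statements on the series, on what has been measured and on what is new or still open speak of the compounds shown alone.

In a functional assay on THP-1 cells (Homo sapiens) for cytotoxicity, read by MTT assay, with a stated time of 24 h (on this read-out higher numbers stand for weaker inhibition and lower numbers for stronger inhibition), compound 1 (`CN1C/C(=C\c2cccc([N+](=O)[O-])c2)C(=O)/C(=C/c2ccccc2F)C1`) gives 1010 nM as the lowest of three numbers, against compound 2 (`COc1cc(/C=C2\CN(C)C/C(=C\c3ccc(F)cc3)C2=O)cc(OC)c1OC`) at 6130 nM and compound 3 (`COc1cc(/C=C2\CN(C)C/C(=C\c3ccc(Br)cc3)C2=O)cc(OC)c1OC`) at 5330 nM on the same read-out. Compound 4 (`CN1C/C(=C\c2ccc(F)cc2)C(=O)/C(=C/c2cccc([N+](=O)[O-])c2)C1`) differs from compound 1 by one change (4-fluorophenyl in place of 2-fluorophenyl on a double-bonded chain carbon bound to a double-bonded ring carbon): 4-fluorophenyl in place of 2-fluorophenyl on a double-bonded chain carbon bound to a double-bonded ring carbon. Going by the values given here, no measured step moves a fluoro group around its ring. Among the compounds with values here, the only step at hand, a 1.2-fold lower number from compound 2 to compound 3 (0.06 log units; within the scatter) for bromo in place of fluoro on an aromatic carbon, stays within the scatter, so only a small change is expected. The estimated move (a 1.4-fold higher number from compound 1 to compound 4 (0.14 log units; within the scatter)) is slightly upward and within the scatter. Compound 4 is estimated at 1400 nM within a range of 550 nM to 3600 nM overall.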

Compound 4, half-maximal inhibitory concentration: 7160 nM
Compound 4: the middle estimate sits 5.1-fold (0.71 log units) below what was measured; measured number outside the range, above it.
By their numbers in this assay, from the lowest: compound 1; then compounds 3, 2 and 4 (each within the scatter of the next).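

In this assay, the place of the fluoro group on this ring matters on its own: 4-fluorophenyl in place of 2-fluorophenyl gives a 7.1-fold higher number from compound 1 to compound 4 (0.85 log units; beyond the scatter), with the same atoms joined differently. Going by these compounds alone, the only earlier step, a 1.2-fold lower number from compound 2 to compound 3 (0.06 log units; within the scatter), exchanged one group for another in a different pair and showed no such move. Nothing available here gives a reason for this shift. On these data alone, whether a chloro group or an amine in place of the fluoro group would give a number near that of compound 1 or that of compound 4 remains open. So does whether moving the fluoro group would count the same way in compound 2.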